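The source may hold more compounds than are shown below. What is called first, only, known or untested is meant among the compounds shown, and "the series" means these compounds.

Measured so far:
compound 1, `COc1ccc(Nc2sc(C(=O)c3ccc(OC)cc3)c(C)c2C(=O)O)cc1`, 51%
compound 2, `COc1ccc(C(=O)c2sc(Nc3ccc(F)cc3)c(C(=O)O)c2C)cc1`, 12.8%

In a functional assay, with a stated time of 150 min, tested at 35 ug/mL (a lower number here means a weaker effect, a higher number a stronger effect of the compound at the concentration tested), compound 2 stands lowest of the two numbers; the nearest is compound 1, with the step from one to the other a number 38.2 percentage points lower from compound 1 to compound 2 (beyond the scatter), a change at the aniline ring only. Compound 3, `Cc1ccc(C(=O)c2sc(Nc3ccc(F)cc3)c(C(=O)O)c2C)cc1`, differs from compound 2 at the other aryl ring: methyl in place of methoxy on an aromatic carbon. Among the measured compounds shown here, no measured step touches this position, so the only step known, a number 38.2 percentage points lower from compound 1 to compound 2 (beyond the scatter), does not bear on it directly; it shows only that this series can move far in this assay on a single change. The swap in compound 3 is small in size, and the expectation is a step within the scatter, with no direction claimed. For compound 3 a value near compound 2 is estimated, 15%, within 3% to 35%, which means an expected step of a number 2.2 percentage points higher from compound 2 to compound 3 (within the scatter).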

Compound 3, a percentage reported as activity, at one concentration (the size of the read-out at that concentration, not a potency): "not active" (no number reported)
The entry for compound 3 holds no number; no gap can be computed for the estimate.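

In this assay, among the compounds shown here, compound 3 is entered as "not active" with no number, so no step from compound 2 to compound 3 can be read. The compounds shown leave open how far the change from 4-methoxyphenyl to 4-methylphenyl moves the read-out. No supporting data bear on this result.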